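Adding a Chlorobenzyl Thioether to the Core of Compound 2

This account rests on a few compounds, and the source may have more. Where it says the series, first, only, none or still open, it means among the compounds named here.

Compound 2 `Cc1cc(Nc2cc(-c3ccccc3)[nH]n2)n2ncnc2n1` reaches only the limit of the assay in an ADME assay on GES1 cells (Homo sapiens) for inhibition, read by MTT assay, with a stated time of 72 h (a higher number here means a weaker inhibitor, a lower number a stronger inhibitor), and is recorded at > 50000 nM. Compound 1 `Cc1ccc(CSc2nc3nc(C)cc(Nc4cc(-c5ccccc5)[nH]n4)n3n2)cc1` carries a (4-methylbenzyl)sulfanyl group on the shared core, and in this assay compound 1 gives 36200 nM. The step of an at least 1.3-fold higher number from compound 1 to compound 2 (0.14 log units; that floor lies within the scatter) is the only measured one bearing on compound 3 `Cc1cc(Nc2cc(-c3ccccc3)[nH]n2)n2nc(SCc3ccc(Cl)cc3)nc2n1`, which introduces ((4-chlorobenzyl)sulfanyl in place of hydrogen on an aromatic carbon). Reversing a step of that size, one expects in this assay a change of an at least 1.4-fold lower number from compound 2 to compound 3 (0.15 log units; that floor lies within the scatter), no larger than the scatter. Compound 3 is therefore estimated at 35000 nM, within 15000 nM to 80000 nM.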

Compound 3, half-maximal inhibitory concentration: 31800 nM
The estimate for compound 3 lay 1.1-fold (0.04 log units) above the measured number; measured number inside the range.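

Chloro in place of methyl on an aromatic carbon gives a 1.1-fold lower number from compound 1 to compound 3 (0.06 log units; within the scatter), so in this assay these two benzyl thioethers cannot be told apart. Placing (4-chlorobenzyl)sulfanyl on the carbon between two ring nitrogen atoms gives an at least 1.5-fold lower number from compound 2 to compound 3 (0.19 log units; that floor lies within the scatter), so this second sulfanyl group also shows no change beyond the scatter. The value of compound 2 is a limit, not a number: the limit of > 50000 nM in this assay, at which 1 of the 3 values shown sits.

As far as these compounds go, how an amine or a carboxylic acid in place of (4-chlorobenzyl)sulfanyl would read remains open. So does whether any group at this carbon moves the number beyond the scatter.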